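Benzothiazolylmethoxy Analogue Follows Two Measured Ethers

This account rests on a few compounds, and the source may have more. Where it says the series, first, only, none or still open, it means among the compounds named here.

Measured in a functional assay on A549 cells (Homo sapiens) for cytotoxicity, read by MTT assay, with a stated time of 72 h; a higher number here means a weaker inhibitor, a lower number a stronger inhibitor:
Compound 1, `CN1CCN(CCCCOc2c(OCc3ccccc3)cc(O)c3c(=O)cc(-c4ccccc4)oc23)CC1`: 2910 nM
Compound 2, `CN1CCN(CCCCOc2c(OCc3ccco3)cc(O)c3c(=O)cc(-c4ccccc4)oc23)CC1`: 3600 nM

Compound 2 and compound 1 sit within the scatter of each other in this assay, the step of a 1.2-fold higher number from compound 1 to compound 2 (0.09 log units; within the scatter) being the only one measured so far. Compound 3, `CN1CCN(CCCCOc2c(OCc3nc4ccccc4s3)cc(O)c3c(=O)cc(-c4ccccc4)oc23)CC1`, differs from compound 2 by 1,3-benzothiazol-2-yl in place of furan-2-yl on a saturated chain carbon bound to an oxygen on an aromatic ring. Among the measured compounds shown here, the one step that bears on this place, a 1.2-fold higher number from compound 1 to compound 2 (0.09 log units; within the scatter), stayed within the scatter, so no step beyond the scatter is expected here either, a 1.1-fold lower number from compound 2 to compound 3 (0.05 log units; within the scatter). Compound 3 is therefore estimated at 3200 nM in this assay, with a range from 1200 nM to 9000 nM.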

Compound 3, half-maximal inhibitory concentration: 1060 nM
Estimate against measurement, compound 3: 3.0-fold (0.48 log units) above, outside the stated range (below it).
By their numbers in this assay, from the lowest: compound 3; then compounds 1 and 2 (each within the scatter of the next).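

The place on the saturated chain carbon bound to an oxygen on an aromatic ring proved responsive in this assay: 1,3-benzothiazol-2-yl gives a 3.4-fold lower number from compound 2 to compound 3 (0.53 log units; beyond the scatter) and a 2.7-fold lower number from compound 1 to compound 3 (0.44 log units; beyond the scatter), although phenyl and furan-2-yl had stayed within the scatter of each other. Among the compounds shown here, both steps are modest, but they are the first at this place to lie beyond the scatter. Nothing available here accounts for the difference.

As far as these compounds go, it remains open whether an unfused thiazol-2-yl or a 1,3-benzoxazol-2-yl would match compound 3 at this place. From the compounds shown here alone, it is also open whether 1,3-benzothiazol-2-yl would have the same effect with a longer chain in place of the butyl linker to the methylpiperazine.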